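Methyl-Capped Nitrogen Series: Thiourea-to-Cyanoguanidine Swap Repeated

The compounds below may be only part of what the source reports. "The series", "measured", "known", "first", "only" and "open" are said of these compounds alone.

Measured compounds:
compound 1 `C/N=C(\S)NCCCCCn1nc(-c2ccccc2)ccc1=O`: 68.9%
compound 2 `C/N=C(/NC#N)NCCCCCn1nc(-c2ccccc2)ccc1=O`: 47.6%
compound 3 `C/N=C(\S)N(C)CCCCn1nc(-c2ccccc2)ccc1=O`: 17.5%

In a functional assay on the whole organism with Rattus norvegicus as the target, at a dose of 100 mg/kg (on this read-out lower numbers stand for less inhibition and higher numbers for more inhibition at the one dose given (going by the name of the read-out)), compound 1 gives the highest of the three numbers, and compound 3 the lowest, with the step of a number 51.4 percentage points lower from compound 1 to compound 3 (beyond the scatter). The cores of compound 1 and compound 3 differ by a group of 6 heavy atoms (3 carbon, 2 nitrogen, 1 sulfur; no ring) in place of a group of 6 heavy atoms (3 carbon, 2 nitrogen, 1 sulfur; no ring), on a saturated chain carbon, four bonds along the chain from an aromatic nitrogen. The change from compound 1 to compound 2 is a group of 6 heavy atoms (3 carbon, 3 nitrogen; no ring) in place of a group of 4 heavy atoms (2 carbon, 1 nitrogen, 1 sulfur; no ring), on an amine nitrogen, with the step of a number 21.3 percentage points lower from compound 1 to compound 2 (beyond the scatter). Compound 4 `C/N=C(/NC#N)N(C)CCCCn1nc(-c2ccccc2)ccc1=O` carries the same kind of change relative to compound 3, (a group of 6 heavy atoms (3 carbon, 3 nitrogen; no ring) in place of a group of 4 heavy atoms (2 carbon, 1 nitrogen, 1 sulfur; no ring), on an amine nitrogen), though here the amine nitrogen's other neighbours are saturated chain carbon, saturated chain carbon, rather than a single saturated chain carbon. Since compound 3 already sits low at 17.5%, a similar downward step is expected but cannot reach as far; the estimated step is a number 9.5 percentage points lower from compound 3 to compound 4 (within the scatter). Compound 4 is therefore expected to give about 8%, between 0% and 25%.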

Compound 4, a percentage reported as inhibition, in the whole organism at one dose (the size of the read-out at that dose, not a potency): 27%
Estimate against measurement, compound 4: 19 percentage points below; the measured number lies above the stated range.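

In this assay the replacement did not carry over from one core to the other, and the two steps differ: the same change on two cores in this assay, a number 21.3 percentage points lower (beyond the scatter) from compound 1 to compound 2 and a number 9.5 percentage points higher (within the scatter) from compound 3 to compound 4, 30.8 percentage points apart, beyond the scatter of two such steps

On the core of compound 3, the change gives a number 9.5 percentage points higher from compound 3 to compound 4 (within the scatter), so no change in the read-out can be claimed there, while the other steps remain clear, with a number 20.6 percentage points lower from compound 2 to compound 4 (beyond the scatter) and a number 41.9 percentage points lower from compound 1 to compound 4 (beyond the scatter). With one pair per core at a single dose, this does not show why the steps differ or how the replacement would behave on any further core.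

The compounds shown leave open whether the methyl on the amine nitrogen or the chain length accounts for the lower numbers. As far as these compounds go, how the replacement behaves with an ethyl group on that nitrogen or with a longer chain also stays open.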